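A few compounds are considered here, and "the series" means these few. Any claim that something is new, unique, unknown or untested is made for them only; others in the source may bear on it.

Compound 1 `CCN(C)c1nc(Cc2c(F)cccc2F)cc(=O)[nH]1`: > 89000 nM, a limit
Compound 2 `O=c1cc(Cc2c(F)cccc2F)nc(N2CCCCCC2)[nH]1`: > 78000 nM, a limit

Both compounds were tested in an ADME assay on MT4 cells (Homo sapiens) for cytotoxicity, read by MTT assay, with a stated time of 4 days; on this read-out higher numbers stand for lower toxicity in this test and lower numbers for higher toxicity in this test. Compound 2 stands at > 78000 nM in this assay, and this is a limit, not a number. Compound 1 gives > 89000 nM, which is also a limit. Neither compound therefore has a true number in this assay.

Compound 3 `CN1CCN(c2nc(Cc3c(F)cccc3F)cc(=O)[nH]2)CC1` has not yet been measured. It keeps the shared core and carries 4-methylpiperazin-1-yl in place of azepan-1-yl on an aromatic carbon, between two ring nitrogen atoms: 4-methylpiperazin-1-yl in place of azepan-1-yl on an aromatic carbon.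

For the measured compounds named here, only one measured step swaps a group on that carbon, and it is a step that the two limits leave unreadable from compound 1 to compound 2. Its size cannot be read, so it offers no shift to carry over. Neither of the two groups tried there has brought a number into view, and no step beyond the scatter is expected in this assay. The expected change is a step that the limit leaves unreadable from compound 2 to compound 3. A limit is the most likely report for compound 3. For compound 3 the estimate is 80000 nM, with an expected range from 30000 nM to 150000 nM.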

Compound 3, half-maximal cytotoxic concentration: > 78000 nM
Compound 3: a limit, no number; the forecaster's own chance of this, stated with the estimate: 75%; the middle value is on the limit's open side.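

Compound 3 also gives > 78000 nM in this assay, which is a limit and not a number. The steps among compound 1, compound 2 and compound 3 therefore cannot be read. The compounds shown leave open whether any group on that aromatic carbon would bring a true number into view in this assay.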